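The source may report more compounds than this note shows. Statements on the series, on what has been measured and on what is new or still open speak of the compounds shown alone.

Measured so far:
compound 1 `C=CCn1c(=O)/c(=C\c2cccc(F)c2)[nH]c(=O)/c1=C\c1ccccc1OC` — in a functional assay on A549 cells (Homo sapiens) for cytotoxicity, read by CCK-8 assay, with a stated time of 72 h (on this read-out higher numbers stand for weaker inhibition and lower numbers for stronger inhibition), compound 1 gives 19700 nM
compound 2 `C=CCn1c(=O)/c(=C\c2cc(F)ccc2C)[nH]c(=O)/c1=C\c1ccccc1OC` — in this assay compound 2 gives 4900 nM

Among the compounds with values here, compound 2 holds the lower of the two numbers; the single measured step is a 4.0-fold lower number from compound 1 to compound 2 (0.60 log units; beyond the scatter), and it separates compound 2 from its only neighbour, compound 1. Compound 3 `C=CCn1c(=O)/c(=C\c2ccccc2F)[nH]c(=O)/c1=C\c1ccccc1OC` carries 2-fluorophenyl in place of 5-fluoro-2-methylphenyl on a double-bonded chain carbon bound to an aromatic carbon. Within the data shown here, this change removes the methyl whose introduction gave a 4.0-fold lower number from compound 1 to compound 2 (0.60 log units; beyond the scatter), while the fluorine shifts to a new ring site for which no measured step exists. The expected outcome is a rise in this assay of roughly the earlier size, with wide uncertainty from the unassessed fluorine shift. Compound 3 is estimated at 15000 nM (range 5000 nM to 45000 nM), meaning an expected step of a 3.1-fold higher number from compound 2 to compound 3 (0.49 log units; beyond the scatter).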

Compound 3, half-maximal inhibitory concentration: "not active" (no number reported)
The entry for compound 3 holds no number; no gap can be computed for the estimate.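

Within the data shown here, compound 3 is recorded as "not active" in this assay with no number, so no step from compound 2 can be read. No evidence bears on this result. The compounds shown leave open how far 2-fluorophenyl differs numerically from 5-fluoro-2-methylphenyl.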